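Arylamino extension at the ring amine of compound 3

A few compounds are considered here, and "the series" means these few. Any claim that something is new, unique, unknown or untested is made for them only; others in the source may bear on it.

Compound 3 `Cc1cc(N)c(=O)n(CC(=O)Nc2ccc(Br)cc2)n1` carries a free amino group on the shared core. In an assay on HL-60 cells for agonist activity at N-formyl peptide receptor 3 (Homo sapiens), read by calcium flux (on this read-out higher numbers stand for an effect only at larger amounts of compound and lower numbers for an effect already at smaller amounts), compound 3 gives > 50000 nM, which is a limit of the assay and not a number. Compound 1 `Cc1cc(Cc2ccsc2)c(=O)n(CC(=O)Nc2ccc(Br)cc2)n1` gives > 50000 nM in this assay, likewise only a limit. Compound 2 `Cc1cc(Cc2cccnc2)c(=O)n(CC(=O)Nc2ccc(Br)cc2)n1` gives > 50000 nM in this assay, again a limit. All three values sit at the limit of > 50000 nM in this assay, at which 3 of the 3 values shown sit, so the steps a step that the two limits leave unreadable from compound 1 to compound 2, a step that the two limits leave unreadable from compound 1 to compound 3 and a step that the two limits leave unreadable from compound 2 to compound 3 cannot be read in size or direction. Compound 4 `COc1ccc(Nc2cc(C)nn(CC(=O)Nc3ccc(Br)cc3)c2=O)cc1` differs from compound 3 by 4-methoxyphenyl in place of hydrogen on a nitrogen on an aromatic ring. Among the compounds with values here, no measured step touches this nitrogen; the two steps that lead to compound 3 exchange (thiophen-3-yl)methyl or (pyridin-3-yl)methyl for amino at the aromatic carbon, and both stay unreadable. Nothing shown therefore supports an expected gain beyond the scatter, and the expected step that the limit leaves unreadable from compound 3 to compound 4 is of unknown direction, with a renewed limit the most probable outcome. Compound 4 is estimated at 60000 nM, within 5000 nM to 200000 nM, with a limit the likeliest report.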

Compound 4, half-maximal effective concentration: > 50000 nM
Compound 4: only a limit was reported; the forecaster's own chance of this, stated with the estimate: 80%; the middle value does not contradict the limit.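

In this assay compound 4 gives > 50000 nM, again a limit of the assay and not a number. Its steps from compound 1, compound 2 and compound 3 cannot be read in size or direction: the limit of > 50000 nM in this assay, at which 4 of the 4 values shown sit. The compounds shown leave open whether any change to the shared core yields a readable value in this assay.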